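Replacing pyrrolidin-1-yl with 1H-imidazol-1-yl in compound 2

The compounds below may be only part of what the source reports. "The series", "measured", "known", "first", "only" and "open" are said of these compounds alone.

Measured in a functional assay on the whole organism for antagonist activity, with Mus musculus as the target; on this read-out lower numbers stand for an effect already at smaller amounts and higher numbers for an effect only at larger amounts of compound:
- Compound 1 `COC(=O)N(C)C(C)C#CCn1ccnc1`: > 100 mg/kg
- Compound 2 `Cn1ccn(CC#CCN2CCCC2)c1=O`: > 10 mg/kg

Neither entry is an exact number. Compound 2 stands at > 10 mg/kg, and this value is a limit of the assay.

Compound 3 `Cn1ccn(CC#CCn2ccnc2)c1=O` has 1H-imidazol-1-yl in place of pyrrolidin-1-yl on a saturated chain carbon bound to a triple-bonded carbon. Compound 1 carries the same 1H-imidazol-1-yl group at such a carbon, and its > 100 mg/kg is also a limit of the assay.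

Among the measured compounds shown here, no measured step shows this exchange directly, so the forecast is rough. Resting on compound 1 at > 100 mg/kg, a shift to larger doses beyond the usual scatter is expected, and the estimated size is a step that the limit leaves unreadable from compound 2 to compound 3. For compound 3 the expected dose in this assay is 60 mg/kg, with an estimated range of 15 mg/kg to 200 mg/kg.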

Compound 3, dose for half-maximal effect: > 100 mg/kg
Compound 3: a limit, no number; the forecaster's own chance of this, stated with the estimate: 70%; at least 1.6-fold (0.22 log units) between middle value and limit.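

Among the compounds shown here, compound 2 and compound 3 both give only limits in this assay, not numbers, and no step between them can be read. The compounds shown leave open what dose either compound needs, and whether 1H-imidazol-1-yl in place of pyrrolidin-1-yl changes that dose at all.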